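Anilinopyrimidine acrylamides: removing the methoxy

The compounds below may be only part of what the source reports. "The series", "measured", "known", "first", "only" and "open" are said of these compounds alone.

Measured compounds:
compound 1, `C=CC(=O)Nc1cccc(Nc2nc(Nc3ccc(OCCn4ccnc4)cc3)ncc2Cl)c1`, gives 1340 nM
compound 2, `C=CC(=O)Nc1cccc(Nc2nc(Nc3ccc(Cn4ccnc4)cc3OC)ncc2Cl)c1`, gives 6780 nM

In a functional assay on A-431 cells (Homo sapiens) for antiproliferative activity, read by MTT assay, with a stated time of 48 h (a higher number here means a weaker inhibitor, a lower number a stronger inhibitor), compound 2 stands at the highest of the two numbers. Among the measured compounds shown here, its nearest neighbour is compound 1, whose value is lower by a margin that lies beyond the scatter; the two differ in more than one place, so the comparison shows only that compound 2 is the weaker of the pair, not which change carries the gap.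

Compound 3, `C=CC(=O)Nc1cccc(Nc2nc(Nc3ccc(Cn4ccnc4)cc3)ncc2Cl)c1`, is not yet measured. It differs from compound 2 by hydrogen in place of methoxy on an aromatic carbon. For the measured compounds named here, no pair of measured compounds differs in that one place alone, so no step can be read directly. Compound 1, which also carries hydrogen at that position, sits at 1340 nM, so a move toward that number is the working expectation for compound 3, with the direction toward a lower value more likely than no change. The estimated step is a 2.7-fold lower number from compound 2 to compound 3 (0.43 log units; beyond the scatter) for compound 3. Compound 3 is expected to give about 2500 nM in this assay, within a range of 800 nM to 8000 nM.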

Compound 3, half-maximal inhibitory concentration: 733 nM
Compound 3: the middle estimate sits 3.4-fold (0.53 log units) above what was measured; the whole stated range lies above it.
By their numbers in this assay, from the lowest: compounds 3 and 1 (each within the scatter of the next); then compound 2.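

In this assay, the step from methoxy to hydrogen on this aromatic carbon, ortho to a large group and meta to the (1H-imidazol-1-yl)methyl group, is a 9.2-fold lower number from compound 2 to compound 3 (0.97 log units; beyond the scatter) and isolates a change that the earlier pair, differing in more than one place, could not separate. With the methoxy gone, the side chain itself can be compared: a 1.8-fold lower number from compound 1 to compound 3 (0.26 log units; within the scatter) separates the (1H-imidazol-1-yl)methyl group from the 2-(1H-imidazol-1-yl)ethoxy group, so this assay does not distinguish the two chains on a ring that carries hydrogen at the methoxy position. No accompanying measurement gives a reason for the size of the methoxy step.

From the compounds shown here alone, the effect of methoxy alongside the 2-(1H-imidazol-1-yl)ethoxy chain cannot be read, so the step is known only with the (1H-imidazol-1-yl)methyl group, and it remains open whether fluorine or an ethoxy group at the same carbon would behave like methoxy or like hydrogen. Also open, going by these compounds, is how the series responds to a longer chain such as 3-(1H-imidazol-1-yl)propoxy, or to a morpholine in place of the imidazole.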